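A few compounds are considered here, and "the series" means these few. Any claim that something is new, unique, unknown or untested is made for them only; others in the source may bear on it.

Measured in an ADME assay on microsomes from liver (Mus musculus) for metabolic stability, read by LC-MS, using NADPH, with a stated time of 60 min, tested at 10 uM; a higher number here means that the compound lasts longer, a lower number that the compound disappears faster:
- compound 1 `O=C([C@@H]1CCCN(S(=O)(=O)c2ccc(S(=O)(=O)C3CCC3)cc2)C1)N1CCC(F)(F)CC1`: 0.733 h
- compound 2 `CC(C)S(=O)(=O)c1ccc(S(=O)(=O)N2CCC[C@@H](C(=O)N3CCC(F)(F)CC3)C2)cc1`: > 1 h (a limit of the assay, not a number)
- compound 3 `CCN(CC)S(=O)(=O)c1ccc(S(=O)(=O)N2CCC[C@@H](C(=O)N3CCC(F)(F)CC3)C2)cc1`: 0.0433 h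

Of the two actual numbers, compound 1 holds the higher, and compound 3 falls well short of it. Compound 2 has only a limit.

Compound 4 `CC(C)NS(=O)(=O)c1ccc(S(=O)(=O)N2CCC[C@@H](C(=O)N3CCC(F)(F)CC3)C2)cc1` is still unmeasured. Its difference from compound 1 is isopropylamino in place of cyclobutyl on a sulfonyl sulfur: cyclobutylsulfonyl becomes isopropylsulfamoyl. Among the compounds with values here, the closest precedent is the diethylamino replacement, a 17-fold lower number from compound 1 to compound 3 (1.23 log units; beyond the scatter). The isopropyl replacement gives an at least 1.3-fold higher number from compound 1 to compound 2 (0.13 log units; that floor lies within the scatter), and the step of an at least 23-fold lower number from compound 2 to compound 3 (1.36 log units; beyond the scatter) is also large. Compound 4 carries the isopropyl of compound 2 together with a nitrogen on the sulfonyl sulfur, as in compound 3. A fall in this assay is therefore expected, though a smaller one than the drop to compound 3 at 0.0433 h. The expected change is a 2.9-fold lower number from compound 1 to compound 4 (0.47 log units; beyond the scatter). Compound 4 is estimated at 0.25 h, with an expected range of 0.07 h to 0.9 h.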

Compound 4, half-life: 0.385 h
Estimate against measurement, compound 4: 1.5-fold (0.19 log units) below, within the range that was stated.
By their numbers in this assay, from the lowest: compound 3; then compounds 4 and 1 (each within the scatter of the next). At a limit, above all of these: compound 2.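

In this assay, a nitrogen on the sulfonyl sulfur does not by itself bring the large fall seen with compound 3: isopropylamino in place of cyclobutyl gives a 1.9-fold lower number from compound 1 to compound 4 (0.28 log units; within the scatter), whereas isopropylamino in place of diethylamino gives an 8.9-fold higher number from compound 3 to compound 4 (0.95 log units; beyond the scatter). Among these compounds, the large fall is therefore tied to diethylamino and not to amino groups at this place in general. Isopropylamino in place of isopropyl gives an at least 2.5-fold lower number from compound 2 to compound 4 (0.41 log units; beyond the scatter), but this step is only a floor, as compound 2 stands at a limit of the assay: the limit of > 1 h in this assay, at which 1 of the 4 values shown sits.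

On these data alone, whether the gap between compound 3 and compound 4 follows the hydrogen-bond donor of isopropylamino or the diethylamino chains remains open. A methylamino or dimethylamino group on the sulfonyl sulfur would help separate the two.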